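The source may report more compounds than this note shows. Statements on the series, on what has been measured and on what is new or still open speak of the compounds shown alone.

Measured so far:
Compound 1, `Cc1cccc2oc(/C=C/[S+](C)[O-])cc(=O)c12`: 1300 nM
Compound 2, `CCCCOc1ccc2oc(/C=C/[S+](C)[O-])cc(=O)c2c1`: 1400 nM

In a functional assay on A549 cells (Homo sapiens) for cytotoxicity, with a stated time of 48 h (on this read-out higher numbers stand for weaker inhibition and lower numbers for stronger inhibition), compound 1 gives 1300 nM, and compound 2 gives 1400 nM. Compound 2 has the higher of the two numbers, but the gap to compound 1 lies within the scatter, so the two compounds cannot be told apart on these data.

Compound 3, `C[S+]([O-])/C=C/c1cc(=O)c2cc(OC(=O)C(C)(C)C)ccc2o1`, differs from compound 2 in one place: (tert-butyl)carbonyl in place of butyl on an oxygen on an aromatic ring. Among the compounds with values here, no pair of measured compounds shows this change, so there is no measured step to lean on; the only guide is that the two measured compounds, with different groups on the same oxygen, sit within the scatter of each other. On that basis the expected step in this assay is a 1.1-fold higher number from compound 2 to compound 3 (0.03 log units; within the scatter), a change not expected to reach beyond the scatter in either direction. Compound 3 is therefore estimated at 1500 nM, with a range from 700 nM to 3500 nM.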

Compound 3, half-maximal inhibitory concentration: 1600 nM
The estimate for compound 3 lay 1.1-fold (0.03 log units) below the measured number, and the stated range covers the measured number.
By their numbers in this assay, from the lowest: compounds 1, 2 and 3 (each within the scatter of the next).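

Within the data shown here, the pair gives the first direct reading at this position: on an oxygen on an aromatic ring, (tert-butyl)carbonyl in place of butyl gives a 1.1-fold higher number from compound 2 to compound 3 (0.06 log units; within the scatter) in this assay. The entering group brings a carbonyl and a hydrogen-bond acceptor and has more heavy atoms and a branched tert-butyl end, yet compound 2 and compound 3 cannot be told apart on this read-out. Nothing available bears on why these two groups read alike.

From the compounds shown here alone, it remains open whether an amine, a carboxylic acid or a much longer chain on this oxygen would separate from butyl beyond the scatter. The compounds shown also leave open whether a free hydroxyl there, or the same exchange at another place on the shared core, would read any differently.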